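The source may hold more compounds than are shown below. What is called first, only, known or untested is meant among the compounds shown, and "the series" means these compounds.

Measured in an ADME assay on MCF-10A cells (Homo sapiens) for antiproliferative activity, read by MTT assay, with a stated time of 72 h (on this read-out lower numbers stand for stronger inhibition and higher numbers for weaker inhibition), so far:
Compound 1 `S=C(SSC1CCCCC1)N1CCCCC1` reads > 10000 nM (a limit)
Compound 2 `CCCCSSC(=S)N(CC)CC` reads > 10000 nM (a limit)
Compound 3 `S=C(SSC(=S)N1CCCC1)N1CCCC1` reads > 10000 nM (a limit)

Among the measured compounds shown here, the three readings share the limit of > 10000 nM in this assay, at which 3 of the 3 values shown sit, and no compound has yet given an actual number. Compound 2 stands at that same place, and its > 10000 nM is a limit and not a number. It therefore cannot be ranked against the other two.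

Compound 4 `CCN(CC)C(=S)SSCCO` differs from compound 2 in one place. The change is hydroxy in place of ethyl on a saturated chain carbon, two bonds along the chain from a sulfur and in words it is hydroxy in place of ethyl on a saturated chain carbon, two bonds along the chain from a sulfur. The same difference, cut one bond further out, reads butyl to 2-hydroxyethyl.

For the measured compounds named here, no step between measured compounds is available to size this change, so the expectation rests on the limits alone. No step beyond the scatter is expected in this assay and no clear direction, since compound 2 reads > 10000 nM as a limit. The expected size of the change is a number no higher from compound 2 to compound 4 (the limit leaves the size open) as estimated here. Compound 4 is estimated at 10000 nM with an expected range from 4000 nM to 20000 nM and a report as a limit alone is the likeliest outcome.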

Compound 4, half-maximal inhibitory concentration: > 10000 nM
Compound 4 gave a limit, no number; the forecaster's own chance of this, stated with the estimate: 80%; the middle value lies on the limit itself.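

Among the compounds shown here, compound 2 and compound 4 both stand at a limit and neither gives a number, so no step from one to the other can be read. The compounds shown leave open what actual number any of them would give in this assay, and so whether hydroxy in place of ethyl changes the reading at all: the limit of > 10000 nM in this assay, at which 4 of the 4 values shown sit.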